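The source may report more compounds than this note shows. Statements on the series, on what has been measured and on what is new or still open speak of the compounds shown alone.

Working notes on the series, which is being followed in an assay on CHO-K1 cells for displacement of a labelled ligand from prostaglandin E2 receptor EP1 subtype (Homo sapiens); a lower number here means a stronger inhibitor, a higher number a weaker inhibitor.

Three compounds carry numbers. Compound 1 `Cc1cc(C(=O)O)nn1C(C)c1cc(Cl)ccc1OCc1ccccc1` gives 10 nM. Compound 2 `Cc1cc(C(=O)Nc2ccccc2)nn1Cc1cc(Cl)ccc1OCc1ccccc1` gives 39.8 nM. Compound 3 `Cc1cc(C(=O)NN2CCOCC2)nn1Cc1cc(Cl)ccc1OCC(C)C` gives 251 nM. Compound 2 holds the second highest of the three numbers; its gap to compound 1 is the smaller one and its gap to compound 3 the larger one, and both gaps lie beyond the scatter of repeated measurements in this assay.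

The next compound, compound 4 `Cc1cc(NC(=O)C2CCCC2)nn1Cc1cc(Cl)ccc1OCc1ccccc1`, is not yet measured in this assay. It differs from compound 2 in one place: (cyclopentylcarbonyl)amino in place of phenylcarbamoyl on an aromatic carbon. One six-membered aromatic ring of carbon only leaves, and one five-membered non-aromatic ring of carbon only enters, on the aromatic carbon of the five-membered aromatic ring that carries the large group and the methyl group.

For the measured compounds named here, no pair of measured compounds differs in exactly one place, so no measured step guides this change. A small step toward a higher number is expected for compound 4, a 2.0-fold higher number from compound 2 to compound 4 (0.30 log units; within the scatter), possibly not beyond the scatter. Compound 4 is estimated at 80 nM, with a range from 25 nM to 250 nM, because compound 2 gives 39.8 nM as the starting point.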

Compound 4, half-maximal inhibitory concentration: 15.9 nM
Estimate against measurement, compound 4: 5.0-fold (0.70 log units) above; measured number below the stated range.
By their numbers in this assay, from the lowest: compounds 1 and 4 (each within the scatter of the next); then compound 2; then compound 3.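

The change gives a 2.5-fold lower number from compound 2 to compound 4 (0.40 log units; beyond the scatter) in this assay, so this aromatic carbon of the five-membered aromatic ring accepts (cyclopentylcarbonyl)amino in place of phenylcarbamoyl with no loss of binding, and a six-membered aromatic ring of carbon only is not required in this group for a number of this size. The step combines two changes: the carbon ring differs, and the amide is turned round so that its nitrogen, not its carbonyl, stands on the aromatic carbon, while the counts of hydrogen-bond donors and acceptors stay the same on both sides. Nothing measured here bears on why the number moves in this direction.

The compounds shown do not separate the ring change from the turning of the amide; benzoylamino or cyclopentylcarbamoyl at this carbon would pull the two apart. Also open, as far as these compounds go, is how far the carbon ring can be varied, for instance with a cyclopropyl or cyclohexyl ring or an open pentanoyl chain on the same amino link.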